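The source may hold more compounds than are shown below. What is called first, only, known or untested is meant among the compounds shown, and "the series" means these compounds.

Compound 2, `C[C@H]1CC[C@@H]2[C@@H](OC(=O)[C@]23CC(c2ccc([N+](=O)[O-])cc2)=NO3)[C@]2(C)C(=O)C=C[C@@]12O`, is one of three compounds that share a core and differ only in the group on the aromatic ring. In a physicochemical assay for lipophilicity (on this read-out higher numbers stand for higher lipophilicity and lower numbers for lower lipophilicity), compound 2 gives 1.37. Its neighbour compound 1, `COc1ccc(C2=NO[C@]3(C2)C(=O)O[C@@H]2[C@H]3CC[C@H](C)[C@]3(O)C=CC(=O)[C@@]23C)cc1`, gives 1.47, and the move is a number 0.10 log units lower from compound 1 to compound 2 (within the scatter), so the two stand level. Compound 3, `Cc1ccc(C2=NO[C@]3(C2)C(=O)O[C@@H]2[C@H]3CC[C@H](C)[C@]3(O)C=CC(=O)[C@@]23C)cc1`, gives 1.86, and here the move is a number 0.49 log units higher from compound 2 to compound 3 (beyond the scatter), while the related move is a number 0.39 log units higher from compound 1 to compound 3 (beyond the scatter). Compound 2 therefore stands at the low end of the three as far as the scatter lets one tell.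

The new compound 4, `C[C@H]1CC[C@@H]2[C@@H](OC(=O)[C@]23CC(c2ccc(F)cc2)=NO3)[C@]2(C)C(=O)C=C[C@@]12O`, differs from compound 2 in one place: fluoro in place of nitro on an aromatic carbon. Two of the measured steps bear on this change, since both remove the nitro group. Replacing nitro with methoxy gave a number 0.10 log units lower from compound 1 to compound 2 (within the scatter) in the other direction, within the scatter, whereas replacing nitro with methyl gave a number 0.49 log units higher from compound 2 to compound 3 (beyond the scatter), a modest rise. For fluoro in place of nitro a rise beyond the scatter is expected in this assay, smaller than the step to methyl. Compound 4 is thus estimated at 1.7, with a range from 1.4 to 2, which corresponds to an expected step of a number 0.33 log units higher from compound 2 to compound 4 (beyond the scatter).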

Compound 4, partition coefficient: 1.58
Estimate against measurement, compound 4: 0.12 log units above, and the stated range covers the measured number.
By their numbers in this assay, from the lowest: compounds 2, 1, 4 and 3 (each within the scatter of the next, the first and the last beyond it).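

In this assay the fluoro group cannot be told apart from any of the other three groups at this place on the ring, with a number 0.21 log units higher from compound 2 to compound 4 (within the scatter) and a number 0.11 log units higher from compound 1 to compound 4 (within the scatter) and also a number 0.28 log units lower from compound 3 to compound 4 (within the scatter) as the three new steps. Compound 3 had stood apart from both earlier neighbours, yet compound 4 now stands level with it and also level with compound 2, even though a number 0.49 log units higher from compound 2 to compound 3 (beyond the scatter) still keeps those two apart, so the four groups no longer fall into two separate sets. The change itself also shows that, for this pair, going from nitro with its 3 heavy atoms and 2 hydrogen-bond acceptors to fluoro with 1 heavy atom and no acceptors can leave the read-out within the scatter.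

The compounds shown leave open whether an amine, a carboxylic acid or a longer chain such as butyl on this aromatic carbon would stand clearly apart from these four. They also leave open whether the same exchange of nitro for fluoro would read the same way on another core or at another place on the ring. Nothing shown here gives a reason for this result.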